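Pentyl to isobutyl on the shared core

The source may report more compounds than this note shows. Statements on the series, on what has been measured and on what is new or still open speak of the compounds shown alone.

Compound 1 `C=C1C(=O)O[C@H]2CC3=C[C@H](C/C(C)=C/[C@@H](OC(=O)/C=C/c4ccc(C(F)(F)F)cc4)[C@H]12)OC3=O` gives 1400 nM
Compound 2 `C=C1C(=O)O[C@H]2CC3=C[C@H](C/C(C)=C/[C@@H](OC(=O)/C=C/c4cccc(OC)c4)[C@H]12)OC3=O` gives > 10000 nM as a limit of the assay
Compound 3 `C=C1C(=O)O[C@H]2CC3=C[C@H](C/C(C)=C/[C@@H](OC(=O)CCCCC)[C@H]12)OC3=O` gives 5900 nM

In a functional assay on NCI-H460 cells (Homo sapiens) for cytotoxicity, read by MTT assay, with a stated time of 48 h (on this read-out higher numbers stand for weaker inhibition and lower numbers for stronger inhibition), compound 3 at 5900 nM holds the higher of the two actual numbers, the other being compound 1 at 1400 nM on the same read-out. Compound 2 offers no number for comparison, since > 10000 nM is a limit.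

Compound 4 `C=C1C(=O)O[C@H]2CC3=C[C@H](C/C(C)=C/[C@@H](OC(=O)CC(C)C)[C@H]12)OC3=O` has not yet been measured. It differs from compound 3 by isopropyl in place of butyl on a saturated chain carbon bound to a carbonyl carbon and the same difference reads as pentyl to isobutyl.

For the measured compounds named here, two measured steps concern the group on that carbonyl carbon. One is an at least 7.1-fold higher number from compound 1 to compound 2 (0.85 log units; beyond the scatter) and the other is an at least 1.6-fold lower number from compound 2 to compound 3 (0.22 log units; that floor lies within the scatter) so changes there can matter, yet neither compares one saturated chain with another. Starting from compound 3 at 5900 nM a change this small gives no firm direction, and no shift beyond the scatter is expected in this assay here. The expected step is a 1.2-fold higher number from compound 3 to compound 4 (0.07 log units; within the scatter) by this estimate. Compound 4 is estimated at 7000 nM with an expected range of 3000 nM to 16000 nM in this assay when it is measured.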

Compound 4, half-maximal inhibitory concentration: 3800 nM
Compound 4: the middle estimate sits 1.8-fold (0.27 log units) above what was measured; measured number inside the range.
By their numbers in this assay, from the lowest: compound 1; then compounds 4 and 3 (each within the scatter of the next). At a limit, above all of these: compound 2.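

In this assay, for the compounds shown here, the pair of compound 3 and compound 4 is the first to compare one saturated chain with another on the carbonyl carbon, and isobutyl in place of pentyl gives a 1.6-fold lower number from compound 3 to compound 4 (0.19 log units; within the scatter), so this change of branching does not move the read-out beyond the scatter. Set against the 2-(3-methoxyphenyl)ethenyl group, isobutyl gives an at least 2.6-fold lower number from compound 2 to compound 4 (0.42 log units; beyond the scatter), a step beyond the scatter, whereas the floor of the matching step with pentyl stayed within it. Compound 2 stands at a limit, so this step is a floor and its full size cannot be read: the limit of > 10000 nM in this assay, at which 1 of the 4 values shown sits.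

The compounds shown leave open whether a longer chain such as octyl, or a saturated ring such as cyclohexyl, on the carbonyl carbon would stay within the scatter of these two chains in this assay or reach the value of compound 1, 1400 nM. They also leave open how a chain ending in an amine or a carboxylic acid would read there.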